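Replacing the Side Chain of Compound 3

A few compounds are considered here, and "the series" means these few. Any claim that something is new, unique, unknown or untested is made for them only; others in the source may bear on it.

In a functional assay for inhibition, read by fluorescence and spectrophotometry, with a stated time of 30 h (on this read-out higher numbers stand for weaker inhibition and lower numbers for stronger inhibition), compound 1 `COc1ccc(-c2cc(=O)c3ccc(O)cc3o2)cc1OC` gives 47400 nM and compound 2 `COc1cc(-c2cc(=O)c3ccc(O)cc3o2)cc(OC)c1OC` gives 51400 nM. Compound 3 `COc1ccc(-c2cc(=O)c3ccc(OCCCN4CCC(CCO)CC4)cc3o2)cc1` gives 43200 nM, which lies within the scatter of both other values. Compound 4 `COc1ccc(-c2cc(=O)c3ccc(OCCCCCN4CCC(C)CC4)cc3o2)cc1` has not yet been measured. Its structure differs by 2-(4-methylpiperidin-1-yl)ethyl in place of 4-(2-hydroxyethyl)piperidin-1-yl on a saturated chain carbon, three bonds along the chain from an oxygen on an aromatic ring, on a saturated chain carbon, three bonds along the chain from an oxygen on an aromatic ring. Among the compounds with values here, the only measured single-place step, a 1.1-fold higher number from compound 1 to compound 2 (0.04 log units; within the scatter), is methoxy in place of hydrogen on an aromatic carbon, so it does not test this change. On these data alone, no shift beyond the scatter is therefore expected in this assay, and the direction remains open. The expected size is a 1.2-fold lower number from compound 3 to compound 4 (0.09 log units; within the scatter). For compound 4 the estimated value is 35000 nM, with an expected range of 10000 nM to 70000 nM.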

Compound 4, half-maximal inhibitory concentration: 55100 nM
Beside the measured number, compound 4's estimate is 1.6-fold (0.20 log units) below it; measured number inside the range.
By their numbers in this assay, from the lowest: compounds 3, 1, 2 and 4 (each within the scatter of the next).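

In this assay, the replacement on a saturated chain carbon, three bonds along the chain from an oxygen on an aromatic ring, gives a 1.3-fold higher number from compound 3 to compound 4 (0.11 log units; within the scatter), so this place now has a direct test. Here the entering group has no hydrogen-bond donor and the number stays within the scatter. No measurement given here explains this result.

On these data alone, whether a morpholine or a carboxylic acid at the end of this chain would give a step beyond the scatter stays open. So do the separate contributions of chain length and the hydroxyl, which change together here.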